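This account rests on a few compounds, and the source may have more. Where it says the series, first, only, none or still open, it means among the compounds named here.

Working notes on the series.

Going by the values given here, compound 1 `O=C(CN[C@H]1CCN(S(=O)(=O)Cc2ccccc2)C1)N1CCN(Cc2cccc(Cl)c2)CC1` is the weakest-looking point among the three measured so far: in a functional assay on K562 cells (Homo sapiens) for cytotoxicity, read by MTT assay, with a stated time of 48 h (a lower number here means a stronger inhibitor, a higher number a weaker inhibitor), compound 1 gives 8600 nM, the highest of the three numbers. Compound 2 `Cc1cc(C)c(CN2CCN(C(=O)CN[C@H]3CCN(S(=O)(=O)Cc4ccccc4)C3)CC2)c(C)c1` gives 3300 nM, and compound 3 `O=C(CN[C@H]1CCN(S(=O)(=O)Cc2ccccc2)C1)N1CCN(Cc2ccc(Cl)cc2Cl)CC1` gives 4300 nM. Both measured steps from compound 1 change the aryl group on the same saturated chain carbon bound to an amine nitrogen in a ring: a 2.6-fold lower number from compound 1 to compound 2 (0.42 log units; beyond the scatter), and a 2.0-fold lower number from compound 1 to compound 3 (0.30 log units; within the scatter), the latter within the scatter. Between compound 2 and compound 3 the step is a 1.3-fold higher number from compound 2 to compound 3 (0.11 log units; within the scatter).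

Compound 4 `COc1ccc(CN2CCN(C(=O)CN[C@H]3CCN(S(=O)(=O)Cc4ccccc4)C3)CC2)cc1` is not yet measured. Relative to compound 1 the change is 4-methoxyphenyl in place of 3-chlorophenyl on a saturated chain carbon bound to an amine nitrogen in a ring. The two steps that bear on it, from compound 1 to compound 2 and from compound 1 to compound 3, are both modest or within the scatter, and neither involves a methoxy group, so nothing here fixes a direction. A step no larger than these, and possibly none beyond the scatter, is expected: a 1.3-fold lower number from compound 1 to compound 4 (0.12 log units; within the scatter). For compound 4 in this assay the estimate is 6500 nM, with a range from 2500 nM to 16000 nM.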

Compound 4, half-maximal inhibitory concentration: 50900 nM
The estimate for compound 4 lay 7.8-fold (0.89 log units) below the measured number; measured number outside the range, above it.
By their numbers in this assay, from the lowest: compounds 2, 3 and 1 (each within the scatter of the next, the first and the last beyond it); then compound 4.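

At this place, on a saturated chain carbon bound to an amine nitrogen in a ring, the choice of aryl group moves this assay much further than compounds 1, 2 and 3 suggested: a 5.9-fold higher number from compound 1 to compound 4 (0.77 log units; beyond the scatter), a 12-fold higher number from compound 3 to compound 4 (1.07 log units; beyond the scatter) and a 15-fold higher number from compound 2 to compound 4 (1.19 log units; beyond the scatter), which makes compound 4 the weakest of the four. Among these compounds, only the 4-methoxyphenyl group carries oxygen or a hydrogen-bond acceptor, while the other aryl groups carry chlorine or methyl. No measurement shown here explains this loss of activity.

Still open, as far as these compounds go, is whether the loss follows the methoxy group itself or its placement on the phenyl ring, which 3-methoxyphenyl and 4-chlorophenyl analogues could help separate. Also open, from the compounds shown here alone, is how unsubstituted phenyl or 4-hydroxyphenyl would compare at this place.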